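The source may hold more compounds than are shown below. What is called first, only, known or untested is meant among the compounds shown, and "the series" means these compounds.

Working notes on the series.

Compound 1 `Nc1nc(SCc2ccccc2)nc2c1nc(O)n2Cc1ccccc1` is the reference point. In a functional assay (spleen, spleen) for activation, with Mus musculus as the target (on this read-out higher numbers stand for an effect only at larger amounts of compound and lower numbers for an effect already at smaller amounts), compound 1 gives 0.1 uM, the lowest of the three numbers in hand. Compound 2 `Nc1ncnc2c1nc(O)n2Cc1cccc2ccccc12` gives 10 uM in this assay, and compound 3 `COc1ccc(Cn2c(O)nc3c(N)ncnc32)cc1` gives 10 uM; both of these sit above compound 1 by a distance beyond the scatter, while compound 2 and compound 3 themselves show the same value. Going by the values given here, compound 2 and compound 3 each carry a hydrogen on the core where compound 1 carries benzylsulfanyl, and each also carries a different group on the ring nitrogen, so no single-change step links them to compound 1.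

Compound 4 `Nc1nc(S)nc2c1nc(O)n2Cc1ccccc1` is the next compound to go into this assay. The change from compound 1 is hydrogen in place of benzyl on a sulfur. Among the compounds with values here, nothing measured isolates this change, so the expectation rests on the spread seen so far: the one compound carrying the benzyl on sulfur is the one with the low number, whereas compound 2, which lacks it, shows 10 uM and compound 3, which also lacks it, shows 10 uM. Compound 4 is therefore expected to move upward, with a 30-fold higher number from compound 1 to compound 4 (1.48 log units; beyond the scatter) estimated as the step, clearly beyond the scatter. The estimate for compound 4 in this assay is 3 uM, within a range of 0.3 uM to 30 uM.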

Compound 4, minimum effective concentration: 10 uM
The estimate for compound 4 lay 3.3-fold (0.52 log units) below the measured number, and the stated range covers the measured number.
By their numbers in this assay, from the lowest: compound 1; then compounds 2, 3 and 4 (each within the scatter of the next).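

In this assay, going by these compounds alone, this is the first step that isolates a single change: hydrogen in place of benzyl on a sulfur gives a 100-fold higher number from compound 1 to compound 4 (2.00 log units; beyond the scatter), a large step beyond the scatter. The earlier compounds shown here differed from compound 1 in more than one place and could not separate the benzylsulfanyl group from the group on the ring nitrogen, whereas this pair shows that, with all else held constant, the low number of compound 1 at 0.1 uM is lost when the benzyl leaves the sulfur. Nothing available explains the size of this step.

On these data alone, it remains open whether the benzyl's aromatic ring is needed or whether a plain alkyl group such as methyl, a longer chain such as butyl, or a saturated cyclohexylmethyl group on the same sulfur would keep the low number. As far as these compounds go, it is also open whether the sulfur itself matters, a question that a benzylamino group in place of benzylsulfanyl would address.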